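The source may report more compounds than this note shows. Statements on the series, on what has been measured and on what is new or still open speak of the compounds shown alone.

Measured so far:
- compound 1, `Cc1ccc(OCC(=O)N(Cc2cccs2)c2c[nH]nc2C)cc1`: 0.4 nM
- compound 2, `Cc1ccc(OCC(=O)N(CCCO)Cc2cccs2)cc1`: 3000 nM

In an assay on HEK293 cells for agonist activity at transient receptor potential cation channel subfamily M member 8 (Homo sapiens), read by fluorescence and calcium flux, with a stated time of 15 min (on this read-out higher numbers stand for an effect only at larger amounts of compound and lower numbers for an effect already at smaller amounts), compound 2 gives the higher of the two numbers, and its nearest neighbour, compound 1, sits far away: a 7500-fold higher number from compound 1 to compound 2 (3.88 log units; beyond the scatter). For the measured compounds named here, that step swaps the whole group on the amide-type nitrogen and is the only step recorded.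

Compound 3, `Cc1ccc(OCC(=O)N(CCO)Cc2cccs2)cc1`, is not yet measured. It differs from compound 2 in one place: hydroxy in place of hydroxymethyl on a saturated chain carbon, two bonds along the chain from an amide-type nitrogen.

Going by the values given here, no measured step bears directly on this change. Among the compounds with values here, the one step recorded, a 7500-fold higher number from compound 1 to compound 2 (3.88 log units; beyond the scatter), concerns a different exchange on the same nitrogen and shows only that the group there weighs heavily on the read-out; it says nothing about shortening the hydroxy-bearing chain by one carbon. With the hydroxy group kept and the chain one link shorter, the working expectation is a change in this assay of no more than the usual scatter, in either direction, so that no change at the digits printed from compound 2 to compound 3 (within the scatter) is expected to be small. The value for compound 3 is therefore estimated at 3000 nM, with a range of 800 nM to 12000 nM.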

Compound 3, half-maximal effective concentration: 900 nM
For compound 3 the middle estimate is 3.3-fold (0.52 log units) above the measured one; measured number inside the range.
By their numbers in this assay, from the lowest: compound 1; then compound 3; then compound 2.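

In this assay, for the compounds shown here, going from 3-hydroxypropyl to 2-hydroxyethyl on the amide-type nitrogen gives a 3.3-fold lower number from compound 2 to compound 3 (0.52 log units; beyond the scatter) and so moves the read-out beyond the scatter, which shows that the length of the hydroxy-bearing chain at this position counts, a point the single earlier step could not address. The shorter chain closes little of the distance to the 3-methyl-1H-pyrazol-4-yl group, since the exchange of that group for 2-hydroxyethyl still gives a 2300-fold higher number from compound 1 to compound 3 (3.35 log units; beyond the scatter) and remains large beside the modest chain step. No measured evidence accounts for either shift.

From the compounds shown here alone, with only these two hydroxy-bearing chains in hand, no trend with chain length can be drawn, and it remains open whether a chain longer than 3-hydroxypropyl would raise the number further or whether an amine or a carboxylic acid in place of the hydroxy would move it in either direction. Also open, going by these compounds, is which part of the 3-methyl-1H-pyrazol-4-yl group goes with the far lower number of compound 1, for instance the ring nitrogen hydrogen or the methyl.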